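The source may hold more compounds than are shown below. What is called first, only, known or untested is meant among the compounds shown, and "the series" means these compounds.

The measured compounds:

Compound 1 `COC(=O)C#CC(O/C=C/C(=O)OC)C1CC1` gives 250 nM in a functional assay on HBL-100 cells (Homo sapiens) for antiproliferative activity, read by sulforhodamine B assay, with a stated time of 48 h; a lower number here means a stronger inhibitor of growth, a higher number a weaker inhibitor of growth.
Compound 2 `CCCCCC(C#CC(=O)OC)O/C=C/C(=O)OC` gives 1900 nM in this assay.
Compound 3 `COC(=O)C#CC(O/C=C/C(=O)OC)C1CCCCC1` gives 2500 nM in this assay.

Compound 1 stands lowest of the three numbers. The step of a 7.6-fold higher number from compound 1 to compound 2 (0.88 log units; beyond the scatter) and the step of a 10-fold higher number from compound 1 to compound 3 (1.00 log units; beyond the scatter) both lie beyond the scatter and both run upward, while the step of a 1.3-fold higher number from compound 2 to compound 3 (0.12 log units; within the scatter) lies within the scatter, so compounds 2 and 3 cannot be told apart on these numbers.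

Compound 4 `COC(=O)C#CC(O/C=C/C(=O)OC)C(C)(C)C` is the next compound. Its change from compound 1 is this:

tert-butyl in place of cyclopropyl on a saturated chain carbon bound to an oxygen on an unsaturated carbon and a triple-bonded carbon

Both steps that bear on it replace the cyclopropyl with a larger saturated group and both raise the number in this assay; the two steps agree in direction and size. A tert-butyl is likewise a larger saturated group on the same saturated chain carbon, so a step of similar size in the same direction is expected, which is a 6.0-fold higher number from compound 1 to compound 4 (0.78 log units; beyond the scatter).

Compound 4 is therefore estimated at 1500 nM in this assay, expected to fall between 500 nM and 4500 nM.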

Compound 4, concentration for 50% growth inhibition: 1800 nM
For compound 4 the middle estimate is 1.2-fold (0.08 log units) below the measured one; the measured number falls inside the stated range.
By their numbers in this assay, from the lowest: compound 1; then compounds 4, 2 and 3 (each within the scatter of the next).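

In this assay, tert-butyl brings a group with no ring to this position, and a 7.2-fold higher number from compound 1 to compound 4 (0.86 log units; beyond the scatter) runs the same way as the steps to pentyl and cyclohexyl, so cyclopropyl now stands apart from three different saturated groups. The steps of a 1.4-fold lower number from compound 3 to compound 4 (0.14 log units; within the scatter) and a 1.1-fold lower number from compound 2 to compound 4 (0.02 log units; within the scatter) both lie within the scatter, so compounds 2, 3 and 4 cannot be told apart, and whether the group is a ring, an unbranched chain or tert-butyl makes no readable difference among them. No measurement shown explains why cyclopropyl differs from the other three groups.

The compounds shown leave open whether a cyclobutyl, an isopropyl or a methyl on this carbon would stay near compound 1 or join the other three. They also leave open how a phenyl or an amine-bearing chain would behave here.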